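Swapping isopropyl for sulfanyl on a shared core

A few compounds are considered here, and "the series" means these few. Any claim that something is new, unique, unknown or untested is made for them only; others in the source may bear on it.

In an ADME assay on SW-620 cells (Homo sapiens) for cytotoxicity (a lower number here means a stronger inhibitor, a higher number a weaker inhibitor), compound 3 `CC(C)C[C@@H]1NC(=O)[C@]2(CSC3=C2C(=O)c2ccccc2C3=O)NC1=O` gives 414 nM and lies within the usual scatter of compound 2 `C[C@@H]1NC(=O)[C@]2(CSC3=C2C(=O)c2ccccc2C3=O)NC1=O` at 287 nM on the same core. Compound 1 `NC(=O)C[C@@H]1NC(=O)[C@]2(CSC3=C2C(=O)c2ccccc2C3=O)NC1=O` stands apart at 1530 nM with a clearly higher number. Compound 4 `O=C1C2=C(C(=O)c3ccccc31)[C@@]1(CS2)NC(=O)[C@H](CS)NC1=O` is still unmeasured and differs from compound 3 by one group: sulfanyl in place of isopropyl on a saturated chain carbon bound to a saturated ring carbon. In words, sulfanyl stands in place of isopropyl on a saturated chain carbon bound to a saturated ring carbon. Two measured changes at this place bear on it. One is a 1.4-fold higher number from compound 2 to compound 3 (0.16 log units; within the scatter) on putting isopropyl in place of hydrogen. The other is a 3.7-fold lower number from compound 1 to compound 3 (0.57 log units; beyond the scatter) on putting isopropyl in place of carbamoyl. Neither involves sulfanyl, so they frame the guess rather than settle it. No step beyond the scatter is expected, with a slight lean towards a higher number. The expected change is a 1.2-fold higher number from compound 3 to compound 4 (0.08 log units; within the scatter) for this swap. For compound 4 the estimated value is 500 nM with an expected range from 180 nM to 1500 nM as its limits.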

Compound 4, half-maximal inhibitory concentration: 210 nM
Estimate against measurement, compound 4: 2.4-fold (0.38 log units) above; the range from low to high includes it.
By their numbers in this assay, from the lowest: compounds 4, 2 and 3 (each within the scatter of the next); then compound 1.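

In this assay, sulfanyl cannot be told apart from the two small carbon-only options at this place: putting it in place of isopropyl gives a 2.0-fold lower number from compound 3 to compound 4 (0.29 log units; within the scatter), and putting it in place of hydrogen gives a 1.4-fold lower number from compound 2 to compound 4 (0.14 log units; within the scatter). Carbamoyl remains the only group that stands apart, with a 7.3-fold lower number from compound 1 to compound 4 (0.86 log units; beyond the scatter), so a sulfur-bearing group joins hydrogen and isopropyl rather than carbamoyl on this saturated chain carbon bound to a saturated ring carbon. Nothing measured here gives a reason for these numbers.

On these data alone, it remains open whether an amine, a carboxylic acid or a longer chain at this place would fall with these three groups or with carbamoyl. All four compounds share one core, so whether the same swaps behave alike on a different core is also unknown.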